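The compounds below may be only part of what the source reports. "The series", "measured", "known", "first", "only" and "open" are said of these compounds alone.

Compound 1 has the structure `O=C(CSc1nnc(-c2ccncc2)o1)N/N=C/c1ccc([N+](=O)[O-])cc1` and compound 2 the structure `O=C(CSc1nnc(-c2ccncc2)o1)N/N=C/c1ccccc1F`; the two share a core and differ only in the ring on the carbon that carries the double bond to nitrogen. In a functional assay on MCF7 cells (Homo sapiens) for cytotoxicity, read by MTT assay, with a stated time of 48 h (on this read-out higher numbers stand for weaker inhibition and lower numbers for stronger inhibition), compound 1 gives 31800 nM, and compound 2 gives 21800 nM. Among the measured compounds shown here, the only step measured so far is a 1.5-fold lower number from compound 1 to compound 2 (0.16 log units; within the scatter), so the two numbers sit within the scatter of each other and neither compound stands apart from the other.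

Compound 3, with the structure `O=C(CSc1nnc(-c2ccncc2)o1)N/N=C/c1cc(Cl)cc(Cl)c1O`, brings a further change at the same place: 3,5-dichloro-2-hydroxyphenyl in place of 2-fluorophenyl on a carbon with a double bond to nitrogen. For the measured compounds named here, the one step that bears on this swap, from compound 1 to compound 2, is within the scatter, and it shows that exchanging one aromatic ring for another at this carbon has so far moved the number little. Going by the values given here, no measured step tells how a ring that carries a hydroxyl and two chlorines behaves here. The expectation is therefore a step of a 1.5-fold lower number from compound 2 to compound 3 (0.16 log units; within the scatter) in this assay, with no clear direction beyond the scatter. Compound 3 is estimated at 15000 nM, in a range from 4000 nM to 50000 nM.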

Compound 3, half-maximal inhibitory concentration: 5920 nM
Compound 3: the middle estimate sits 2.5-fold (0.40 log units) above what was measured; measured number inside the range.
By their numbers in this assay, from the lowest: compound 3; then compounds 2 and 1 (each within the scatter of the next).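

In this assay, the ring on the carbon with a double bond to nitrogen can move the number beyond the scatter after all: 3,5-dichloro-2-hydroxyphenyl gives a 3.7-fold lower number from compound 2 to compound 3 (0.57 log units; beyond the scatter) and also a 5.4-fold lower number from compound 1 to compound 3 (0.73 log units; beyond the scatter), so compound 3 is the strongest of the three compounds shown. Compared with 2-fluorophenyl, the entering group brings a hydroxyl and two chlorines in place of one fluorine, and it adds a hydrogen-bond donor and a hydrogen-bond acceptor, so this single change alters several things at once and cannot be credited to any one of them. No measurement given here explains why the number falls with this ring.

The compounds shown leave open whether the hydroxyl, the chlorines or only their combination goes with the lower number, a question that 2-hydroxyphenyl and 3,5-dichlorophenyl at the same carbon would help to separate. They also leave open how this carbon tolerates rings that carry an amine or a carboxylic acid, and whether any such ring would take the number lower than in compound 3.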